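The source may report more compounds than this note shows. Statements on the series, on what has been measured and on what is new or still open speak of the compounds shown alone.

Of the compounds shown here, two have been measured in a functional assay on MDA-MB-231 cells (Homo sapiens) for antiproliferative activity, read by MTT assay, with a stated time of 72 h; on this read-out lower numbers stand for stronger inhibition and higher numbers for weaker inhibition. Compound 1 `O=C(CCc1cccc2c1B(O)OC2)Nc1ccc(I)cc1` gives 33000 nM, and compound 2 `O=C(CCc1cccc2c1B(O)OC2)Nc1cccc(Br)c1` gives 720 nM. Among the measured compounds shown here, the single measured step between them, a 46-fold lower number from compound 1 to compound 2 (1.66 log units; beyond the scatter), is large and well beyond the scatter. On the numbers shown, compound 2 therefore stands as the lower of the two, with compound 1 the only neighbour and a much higher number.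

Compound 3 `N#Cc1cccc(-c2cccc(NC(=O)CCc3cccc4c3B(O)OC4)c2)c1` is the next compound, still unmeasured in this assay. Its change from compound 2 is 3-cyanophenyl in place of bromo on an aromatic carbon. For the measured compounds named here, the one measured step bears only loosely on this: it swapped one halogen atom for another and moved it, whereas here the bromo leaves and a whole 3-cyanophenyl ring enters at the same place. Going by the values given here, no measured pair shows what such a ring does here, so the direction cannot be read from the data, and a wide range is appropriate. In this assay compound 3 is estimated at 1500 nM, with a range from 300 nM to 8000 nM. That expected change amounts to a step of a 2.1-fold higher number from compound 2 to compound 3 (0.32 log units; beyond the scatter), within or near the scatter.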

Compound 3, half-maximal inhibitory concentration: 110 nM
The estimate for compound 3 lay 14-fold (1.13 log units) above the measured number; measured number below the stated range.
By their numbers in this assay, from the lowest: compound 3; then compound 2; then compound 1.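

In this assay, the place meta to a large group takes far more than a single halogen: bromo, 1 heavy atom, gives way to 3-cyanophenyl, 8 heavy atoms, and the result is a 6.5-fold lower number from compound 2 to compound 3 (0.82 log units; beyond the scatter). The earlier step only exchanged one halogen-bearing ring for another, so it could not show that a whole second aromatic ring is accepted here, let alone that the number would fall by more than the scatter. Nothing available explains this drop.

The compounds shown leave open whether the lower number comes from the added ring alone or also needs its nitrile, a question that a plain phenyl ring at the same place would help settle. Going by these compounds, it also remains open how the number would move with an amine or a carboxylic acid in place of the nitrile, or with a saturated ring such as cyclohexyl in place of the added aromatic ring.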